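Removing an Aryl Methyl Group on Two Related Cores

This account rests on a few compounds, and the source may have more. Where it says the series, first, only, none or still open, it means among the compounds named here.

Compound 1 `COc1ccccc1-c1cc(=O)[nH]n1-c1ccc(C(=O)NNC(=O)CO[N+](=O)[O-])cc1` was tested in a functional assay on the whole organism (strain Wistar) for inhibition, with Rattus norvegicus as the target, read by paw edema, with stated times of 3 h and 1 h, at a dose of 6 mg/kg by the oral route (a higher number here means more inhibition at the dose given (going by the name of the read-out), a lower number less inhibition), where compound 1 gave 57.9%. Compound 2 `O=C(CO[N+](=O)[O-])NNC(=O)c1ccc(-n2[nH]c(=O)cc2-c2ccccc2O)cc1` differs from it by hydrogen in place of methyl on an oxygen on an aromatic ring; in this assay compound 2 gave 16.4%, so that a number 41.5 percentage points lower from compound 1 to compound 2 (beyond the scatter). Compound 3 `CCOC(=O)c1c(-c2ccccc2OC)n(-c2ccc(C(=O)NNC(=O)CO[N+](=O)[O-])cc2)[nH]c1=O` has a core that differs from the core of compound 1 by ethoxycarbonyl in place of hydrogen on an aromatic carbon; in this assay compound 3 gave 25.1%, and a number 32.8 percentage points lower from compound 1 to compound 3 (beyond the scatter). Compound 4 `CCOC(=O)c1c(-c2ccccc2O)n(-c2ccc(C(=O)NNC(=O)CO[N+](=O)[O-])cc2)[nH]c1=O` has not yet been measured. Among the compounds with values here, it differs from compound 3 by hydrogen in place of methyl on an oxygen on an aromatic ring, the same change as the one from compound 1 to compound 2, made at the same place on the other core. That earlier step was large and downward, but compound 3 begins from a smaller number, so the room for a fall is limited. The step from compound 3 to compound 4 is therefore expected to be a number 17.1 percentage points lower from compound 3 to compound 4 (beyond the scatter), because of a number 41.5 percentage points lower from compound 1 to compound 2 (beyond the scatter) seen on the first core. Compound 4 is thus estimated to give 8% in this assay, most likely between 0% and 22%.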

Compound 4, a percentage reported as inhibition, in the whole organism at one dose (the size of the read-out at that dose, not a potency): 21.1%
Compound 4: the middle estimate sits 13.1 percentage points below what was measured; low and high end bracket the measured number.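

The change from 2-methoxyphenyl to 2-hydroxyphenyl did not carry over from one core to the other in this assay. On the core bearing ethoxycarbonyl it gave a number 4 percentage points lower from compound 3 to compound 4 (within the scatter), far from the step on the core of compound 1: the same change on two cores in this assay, a number 41.5 percentage points lower (beyond the scatter) from compound 1 to compound 2 and a number 4 percentage points lower (within the scatter) from compound 3 to compound 4, 37.5 percentage points apart, beyond the scatter of two such steps

Seen the other way round, the ethoxycarbonyl change also depended on its partner, giving a number 4.7 percentage points higher from compound 2 to compound 4 (within the scatter), against a clear fall with methoxy in place: the same change on two cores in this assay, a number 32.8 percentage points lower (beyond the scatter) from compound 1 to compound 3 and a number 4.7 percentage points higher (within the scatter) from compound 2 to compound 4, 37.5 percentage points apart, beyond the scatter of two such steps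

This shows that the two changes are not additive in these four compounds, but a single square at one dose and one read-out does not explain the mismatch, and it cannot say how the methoxy to hydroxy change would behave on any further core.

The compounds shown leave open whether a longer chain on that oxygen would keep or lose the number seen with methoxy. They also leave open whether a carboxylic acid or an amine in place of ethoxycarbonyl would behave as ethoxycarbonyl does.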